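From Methyl to Propargyl at the Cytotoxicity Limit

A few compounds are considered here, and "the series" means these few. Any claim that something is new, unique, unknown or untested is made for them only; others in the source may bear on it.

In a functional assay on Vero cells (Chlorocebus sabaeus) for cytotoxicity (on this read-out higher numbers stand for lower toxicity in this test and lower numbers for higher toxicity in this test), compound 1 `Nc1nc(O)c2ncn(C[C@]3(CO)C[C@H]3CO)c2n1` gives 240 ug/mL as a measured number. Compound 2 `O=c1[nH]c(=O)n(CC(CO)C2CC2O)cc1/C=C/Br` returns > 500 ug/mL as a limit of the assay and not a number. Compound 3 `Cc1cn(CC2(CO)CC2CO)c(=O)[nH]c1=O` likewise returns > 500 ug/mL as a limit and not a number. Compound 3 thus stands at the limit of > 500 ug/mL in this assay, at which 2 of the 3 values shown sit, and has no exact figure.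

The change to compound 4 `C#CCc1cn(CC2(CO)CC2CO)c(=O)[nH]c1=O` is ethynyl in place of hydrogen on a saturated chain carbon bound to an aromatic carbon in a step that reads methyl to propargyl, with ethynyl in place of hydrogen on a saturated chain carbon bound to an aromatic carbon. Among the compounds with values here, no measured pair shows this change, so the expectation rests only on compound 3 with its limit of > 500 ug/mL as the starting point. No step beyond the usual scatter is expected in this assay and no direction is predicted. The estimated step of a number no higher from compound 3 to compound 4 (the limit leaves the size open) is accordingly expected to be small. Compound 4 is expected at 500 ug/mL with an estimated range from 200 ug/mL to 1000 ug/mL in this read-out.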

Compound 4, half-maximal cytotoxic concentration: > 500 ug/mL
Compound 4: a limit, no number (the forecaster's own chance of this, stated with the estimate: 70%); the middle value lies on the limit itself.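

Compound 3 and compound 4 both return limits of the assay rather than numbers, so no step can be read between them, because both sit at the same ceiling: the limit of > 500 ug/mL in this assay, at which 3 of the 4 values shown sit.

The compounds shown leave open whether going from methyl to propargyl changes the read-out in this assay at all, and in which direction.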